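This account rests on a few compounds, and the source may have more. Where it says the series, first, only, none or still open, it means among the compounds named here.

Measured so far:
compound 1 `Cc1nc(C)c(/C=C/C(=O)/C=C/c2ccc(O)cc2)nc1C` gives 4010 nM
compound 2 `COc1cc(/C=C/C(=O)/C=C/c2nc(C)c(C)nc2C)ccc1O` gives 2190 nM
compound 3 `COc1ccc(/C=C/C(=O)/C=C/c2nc(C)c(C)nc2C)c(OC)c1` gives 3070 nM

In a functional assay on A549 cells (Homo sapiens) for antiproliferative activity, read by MTT assay, with a stated time of 72 h (a higher number here means a weaker inhibitor, a lower number a stronger inhibitor), compound 1 stands level with compound 2 and compound 3, its gap to each lying within the scatter. Among the measured compounds shown here, the next change leads to compound 4 `Cc1nc(C)c(/C=C/C(=O)/C=C/c2ccc([N+](=O)[O-])cc2)nc1C` and is nitro in place of hydroxy on an aromatic carbon, para to a large group: nitro in place of hydroxy on an aromatic carbon with no measurement yet. For the measured compounds named here, the one measured step, a 1.8-fold lower number from compound 1 to compound 2 (0.26 log units; within the scatter) for methoxy in place of hydrogen on an aromatic carbon, lies within the scatter and leaves the hydroxy in place, so it bears only loosely on this change. Compound 3 carries no hydroxy and gives 3070 nM in the same range as compound 1. Going by the values given here, no measured compound carries nitro, so the range has to stay wide. No step beyond the scatter is therefore expected in this assay in either direction. The expected step is a 1.3-fold lower number from compound 1 to compound 4 (0.13 log units; within the scatter) and it is estimated to stay within the scatter. Compound 4 is estimated at 3000 nM (expected range 1000 nM to 9000 nM for now).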

Compound 4, half-maximal inhibitory concentration: 9600 nM
Estimate against measurement, compound 4: 3.2-fold (0.51 log units) below; measured number above the stated range.
By their numbers in this assay, from the lowest: compounds 2, 3 and 1 (each within the scatter of the next); then compound 4.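

In this assay, nitro in place of hydroxy on an aromatic carbon, para to a large group, gives a 2.4-fold higher number from compound 1 to compound 4 (0.38 log units; beyond the scatter), the only step shown that lies beyond the scatter. This position is therefore not indifferent to the group it carries, though the step is modest, and the earlier methoxy step, being within the scatter, could not show this. Hydroxy and nitro differ at once in heavy atoms, hydrogen-bond donors and hydrogen-bond acceptors, and no measured property bears on this step.

Going by these compounds, it remains open whether the higher number follows from nitro entering or from hydroxy leaving. An amine, a chlorine or a carboxylic acid on the same carbon of the core of compound 1 would help separate the two readings.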